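Aryl exchange at the five-membered ring of the shared core

A few compounds are considered here, and "the series" means these few. Any claim that something is new, unique, unknown or untested is made for them only; others in the source may bear on it.

Compound 1 `O=C(O)Cc1sc(C(c2ccc(F)cc2)c2ccc(F)cc2)nc1-c1cc(F)cc(F)c1` and compound 2 `N#Cc1cc(-c2nc(C(c3ccc(F)cc3)c3ccc(F)cc3)sc2CC(=O)O)ccc1F` share a core and differ only in the aryl group attached to an aromatic carbon of the five-membered ring. In an in vitro assay on HEK385-7 cells for displacement of a labelled ligand from prostaglandin D2 receptor 2 (Homo sapiens) (on this read-out lower numbers stand for stronger inhibition and higher numbers for weaker inhibition), compound 1 gives 35 nM, and compound 2 gives 57 nM. Within the data shown here, the single measured step, a 1.6-fold higher number from compound 1 to compound 2 (0.21 log units; within the scatter), is an aryl exchange at that carbon. Compound 2 stands at the higher of the two numbers, but its gap to compound 1 lies within the scatter, so the two cannot be ordered.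

Compound 3 `CS(=O)(=O)Nc1cccc(-c2nc(C(c3ccc(F)cc3)c3ccc(F)cc3)sc2CC(=O)O)c1` differs from compound 2 by 3-(methanesulfonamido)phenyl in place of 3-cyano-4-fluorophenyl on an aromatic carbon. Among the measured compounds shown here, the only step that bears on this change is a 1.6-fold higher number from compound 1 to compound 2 (0.21 log units; within the scatter), an aryl exchange at the same aromatic carbon that moved the number within the scatter. The entering group carries 1 hydrogen-bond donor where the leaving group has none, but nothing measured connects that to a shift in this assay. The step of a 1.2-fold higher number from compound 2 to compound 3 (0.09 log units; within the scatter) is therefore expected to stay within the scatter. For compound 3 the estimate in this assay is 70 nM, with a range from 20 nM to 250 nM.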

Compound 3, half-maximal inhibitory concentration: 40 nM
Estimate against measurement, compound 3: 1.8-fold (0.24 log units) above; the range from low to high includes it.
By their numbers in this assay, from the lowest: compounds 1, 3 and 2 (each within the scatter of the next).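

Read in this assay, the new aryl group leaves the number unresolved from both earlier compounds: replacing 3-cyano-4-fluorophenyl gives a 1.4-fold lower number from compound 2 to compound 3 (0.15 log units; within the scatter), and replacing 3,5-difluorophenyl gives a 1.1-fold higher number from compound 1 to compound 3 (0.06 log units; within the scatter). Until now, this aromatic carbon, next to the ring nitrogen, had shown only an exchange between two fluorinated aryl groups; compound 3 extends the tolerated set to a 3-(methanesulfonamido)phenyl group of 11 heavy atoms, with a hydrogen-bond donor that 3-cyano-4-fluorophenyl lacks and no fluorine or nitrile, and none of the three compounds can be ordered against another. No measurement available here accounts for this flat result.

Still open, from the compounds shown here alone, is whether the hydrogen-bond donor of the sulfonamide plays any part in the number, which an N-methyl methanesulfonamide on the same phenyl ring would test directly. Going by these compounds, it is also open whether this flat behaviour extends to an aminomethyl group or a carboxylic acid on that phenyl ring, or to a longer chain in place of the methanesulfonamido group.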